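Benzyl amine variants on the bis(trifluoromethyl)sulfonamide core

A few compounds are considered here, and "the series" means these few. Any claim that something is new, unique, unknown or untested is made for them only; others in the source may bear on it.

Three compounds of the series have numbers in a functional assay on BXPC-3 cells (Homo sapiens) for inhibition, read by MTT assay, with a stated time of 72 h; on this read-out lower numbers stand for stronger inhibition of growth and higher numbers for weaker inhibition of growth. Compound 1 `O=S(=O)(NCCCNCc1ccccc1Cl)c1cc(C(F)(F)F)cc(C(F)(F)F)c1` gives 11000 nM. Compound 2 `O=S(=O)(NCCCCNCc1ccc(Br)cc1)c1cc(C(F)(F)F)cc(C(F)(F)F)c1` gives 1700 nM, and compound 3 `O=S(=O)(NCCCNCc1ccc(Cl)c(Cl)c1)c1cc(C(F)(F)F)cc(C(F)(F)F)c1` gives 1400 nM. Compound 3 sits at the low end of the three, though its pair with compound 2, a 1.2-fold lower number from compound 2 to compound 3 (0.08 log units; within the scatter), is not separated from it; the gap to compound 1, a 7.9-fold lower number from compound 1 to compound 3 (0.90 log units; beyond the scatter), is clear, as is a 6.5-fold lower number from compound 1 to compound 2 (0.81 log units; beyond the scatter).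

Compound 4 `CN(CCCNS(=O)(=O)c1cc(C(F)(F)F)cc(C(F)(F)F)c1)Cc1ccccc1` is not yet measured. It differs from compound 3 by benzyl(methyl)amino in place of (3,4-dichlorobenzyl)amino on a saturated chain carbon, three bonds along the chain from a sulfonamide nitrogen. Among the compounds with values here, no measured step removes all ring halogens or replaces the amine hydrogen, so the expectation rests on indirect evidence only: the change of halogen pattern in a 7.9-fold lower number from compound 1 to compound 3 (0.90 log units; beyond the scatter) moved the number a good deal, while a 1.2-fold lower number from compound 2 to compound 3 (0.08 log units; within the scatter) did not. On that basis compound 4 is expected to give a higher number than compound 3, estimated as a step of a 5.7-fold higher number from compound 3 to compound 4 (0.76 log units; beyond the scatter) in this assay. The estimate for compound 4 is 8000 nM, with a range from 2500 nM to 25000 nM.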

Compound 4, concentration for 50% growth inhibition: 39000 nM
Beside the measured number, compound 4's estimate is 4.9-fold (0.69 log units) below it; the measured number lies above the stated range.
By their numbers in this assay, from the lowest: compounds 3 and 2 (each within the scatter of the next); then compound 1; then compound 4.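

In this assay, benzyl(methyl)amino on this saturated chain carbon gives the highest number of the four compounds, with a 28-fold higher number from compound 3 to compound 4 (1.44 log units; beyond the scatter), a 23-fold higher number from compound 2 to compound 4 (1.36 log units; beyond the scatter) and a 3.5-fold higher number from compound 1 to compound 4 (0.55 log units; beyond the scatter), so the position can lose far more than the halogen-bearing benzyl amines alone revealed. The entering group has no ring halogen and 0 hydrogen-bond donors, against 1 in (3,4-dichlorobenzyl)amino, so the large step combines both differences and cannot assign the loss to either. No supporting measurement is available to explain the step.

On these data alone, whether the ring halogens or the amine hydrogen matter more stays open; a plain benzylamino group or a (3,4-dichlorobenzyl)(methyl)amino group at this place would separate them. As far as these compounds go, the effect of chain length alone also stays open, as the ((4-bromobenzyl)amino)methyl group of compound 2 changes chain and ring together.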